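This account rests on a few compounds, and the source may have more. Where it says the series, first, only, none or still open, it means among the compounds named here.

Compound 1 `COc1ccc(C2N=C(SCc3ccccc3)NC(C)=C2C(=O)Nc2ccc(F)cc2)cc1OC` and compound 2 `COc1ccc(C2N=C(SCc3ccc(Cl)cc3)NC(C)=C2C(=O)Nc2ccc(F)cc2)cc1OC` share one core, while compound 3 `COc1ccc(C2N=C(SCc3ccccc3)NC(C)=C2C(=O)Nc2ccc(Br)cc2)cc1` is built on a second core; the difference between the two cores is not broken down here. In a functional assay on the whole organism (artery, strain albino) with Rattus norvegicus as the target, with a stated time of 300 min, at a dose of 10 mg/kg by the oral route (on this read-out higher numbers stand for more inhibition at the one dose given (going by the name of the read-out) and lower numbers for less inhibition), compound 1 gives 7.2%, compound 2 gives 31.3%, and compound 3 gives 16.4%. The change from compound 1 to compound 2 is chloro in place of hydrogen on an aromatic carbon, and in this assay it produced the step of a number 24.1 percentage points higher from compound 1 to compound 2 (beyond the scatter). Compound 4 `COc1ccc(C2N=C(SCc3ccccc3Cl)NC(C)=C2C(=O)Nc2ccc(Br)cc2)cc1` is made from compound 3 by chloro in place of hydrogen on an aromatic carbon. The two changes are the same kind of change, not the same: in compound 2 the chloro sits para to a large group, whereas in compound 4 it sits ortho to a large group. Among the measured compounds shown here, only one measured pair shows this kind of change, and none shows a chloro ortho to a large group, so the expected gain is set smaller than the measured one. The step expected in this assay is a number 13.6 percentage points higher from compound 3 to compound 4 (beyond the scatter), beside the measured a number 24.1 percentage points higher from compound 1 to compound 2 (beyond the scatter). Compound 4 is estimated to give 30% in this assay, within a range from 10% to 50%.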

Compound 4, a percentage reported as inhibition, in the whole organism at one dose (the size of the read-out at that dose, not a potency): 17.9%
Estimate against measurement, compound 4: 12.1 percentage points above, within the range that was stated.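

In this assay, placing a chloro on compound 3 gives a step of a number 1.5 percentage points higher from compound 3 to compound 4 (within the scatter), so the clear gain seen with the same kind of change on the core of compound 1 does not reappear, and the two steps differ: the same change on two cores in this assay, a number 24.1 percentage points higher (beyond the scatter) from compound 1 to compound 2 and a number 1.5 percentage points higher (within the scatter) from compound 3 to compound 4, 22.6 percentage points apart, beyond the scatter of two such steps This shows that, in this series, the gain from a chloro on the benzyl ring cannot simply be assumed to carry over from one compound pair to another. Among the compounds shown here, it does not show what causes the difference, since the two pairs differ in their cores and also in where the chloro stands, ortho to a large group in compound 4 but not in compound 2, and with only one pair of each kind, these two differences cannot be separated.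

The compounds shown leave open what the 2-chlorobenzyl group would do on the core of compound 1, and what a chloro placed as in compound 2 would do on the core of compound 3. They also leave open how an amine or a carboxylic acid on that benzyl ring would change the inhibition.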